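Anilide variants on a shared chromone acrylamide core

The compounds below may be only part of what the source reports. "The series", "measured", "known", "first", "only" and "open" are said of these compounds alone.

Measured so far in a functional assay on A549 cells (Homo sapiens) for inhibition, read by MTT assay, with a stated time of 48 h; a higher number here means a weaker inhibitor, a lower number a stronger inhibitor:
compound 1 `COc1ccc2c(=O)c(/C=C/C(=O)Nc3cc(C)ccc3C)coc2c1`: 15500 nM
compound 2 `COc1ccc(NC(=O)/C=C/c2coc3cc(OC)ccc3c2=O)cc1`: 23000 nM
compound 3 `COc1ccc2c(=O)c(/C=C/C(=O)Nc3ccccc3OC)coc2c1`: reported only as a limit, > 100000 nM

Compound 1 holds the lowest of the two numbers given; compound 2 sits at a 1.5-fold higher number from compound 1 to compound 2 (0.17 log units; within the scatter), so the two cannot be ranked. Compound 3 returned a limit of the assay and no number, as recorded in the limit of > 100000 nM in this assay, at which 1 of the 3 values shown sits, which is an at least 6.4-fold higher number from compound 1 to compound 3 (0.80 log units; beyond the scatter) and an at least 4.3-fold higher number from compound 2 to compound 3 (0.63 log units; beyond the scatter).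

Compound 4 `COc1ccc2c(=O)c(/C=C/C(=O)Nc3ccc(C)cc3)coc2c1` differs from compound 1 in one place: 4-methylphenyl in place of 2,5-dimethylphenyl on an amide-type nitrogen

Among the compounds with values here, two measured steps bear on this. The move to 4-methoxyphenyl, a group that also carries a single substituent on the ring, cost only a 1.5-fold higher number from compound 1 to compound 2 (0.17 log units; within the scatter), within the scatter. The move to 2-methoxyphenyl, by contrast, cost an at least 6.4-fold higher number from compound 1 to compound 3 (0.80 log units; beyond the scatter), beyond the scatter. The 4-methylphenyl change resembles the first step more than the second, so in this assay no step beyond the scatter is expected, with a slight lean toward a higher number. Compound 4 is therefore estimated at 20000 nM, between 8000 nM and 60000 nM, that is an expected 1.3-fold higher number from compound 1 to compound 4 (0.11 log units; within the scatter).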

Compound 4, half-maximal inhibitory concentration: 17500 nM
Compound 4: middle estimate off by 1.1-fold (0.06 log units), on the high side; the measured number falls inside the stated range.
By their numbers in this assay, from the lowest: compounds 1, 4 and 2 (each within the scatter of the next). At a limit, above all of these: compound 3.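

In this assay, 4-methylphenyl on the amide-type nitrogen cannot be told apart from 2,5-dimethylphenyl, with a 1.1-fold higher number from compound 1 to compound 4 (0.05 log units; within the scatter), so the second methyl of compound 1 has no readable effect on the number here. Methyl in place of methoxy on the aromatic carbon also stays within the scatter, with a 1.3-fold lower number from compound 2 to compound 4 (0.12 log units; within the scatter), which leaves compounds 1, 2 and 4 unranked. Compound 3, with 2-methoxyphenyl, remains separate from this group, with an at least 5.7-fold lower number from compound 3 to compound 4 (0.75 log units; beyond the scatter), and its entry is a limit rather than a number: the limit of > 100000 nM in this assay, at which 1 of the 4 values shown sits.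

From the compounds shown here alone, the true size of the gap to compound 3 stays unknown, as does whether it follows from the methoxy group itself or from where it sits on the ring. Going by these compounds, how an amine or a carboxylic acid on the phenyl ring would read also remains open.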